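This account rests on a few compounds, and the source may have more. Where it says the series, first, only, none or still open, it means among the compounds named here.

Compound 3 `CC(C)C(c1cnc(N)s1)c1ccc(-c2ccc3cccc(F)c3c2)[nH]c1=O` stands in the middle of three measured compounds: in a functional assay on CHO cells for antagonist activity at prostaglandin E2 receptor EP3 subtype (Homo sapiens), read by cAMP accumulation (on this read-out higher numbers stand for weaker inhibition and lower numbers for stronger inhibition), compound 3 gives 39 nM, while compound 1 `CC(C)C(c1ncc[nH]1)c1ccc(-c2ccc3cccc(F)c3c2)[nH]c1=O` gives 33 nM and compound 2 `CC(C)C(CC(N)=O)c1ccc(-c2ccc3cccc(F)c3c2)[nH]c1=O` gives 53 nM. The steps of a 1.2-fold higher number from compound 1 to compound 3 (0.07 log units; within the scatter) and a 1.4-fold lower number from compound 2 to compound 3 (0.13 log units; within the scatter) both lie within the scatter, as does a 1.6-fold higher number from compound 1 to compound 2 (0.21 log units; within the scatter). Compound 4 `CC(C)C(Cc1noc(=O)[nH]1)c1ccc(-c2ccc3cccc(F)c3c2)[nH]c1=O` differs from compound 3 by a group of 7 heavy atoms (3 carbon, 2 nitrogen, 2 oxygen; one five-membered aromatic ring with 3 hetero atoms) in place of a group of 6 heavy atoms (3 carbon, 2 nitrogen, 1 sulfur; one five-membered aromatic ring with 2 hetero atoms), on a saturated chain carbon bound to an aromatic carbon and a saturated chain carbon. Every exchange so far at this saturated chain carbon left the number within the scatter, and the new group again brings one hydrogen-bond donor and three acceptors, so no change beyond the scatter is expected from a 1.2-fold higher number from compound 3 to compound 4 (0.06 log units; within the scatter). Compound 4 is therefore estimated at 45 nM, with a range from 20 nM to 100 nM.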

Compound 4, half-maximal inhibitory concentration: 70 nM
Estimate against measurement, compound 4: 1.6-fold (0.19 log units) below; measured number inside the range.
By their numbers in this assay, from the lowest: compounds 1, 3, 2 and 4 (each within the scatter of the next, the first and the last beyond it).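

The exchange of 2-amino-1,3-thiazol-5-yl for the new ring stays within the scatter (a 1.8-fold higher number from compound 3 to compound 4 (0.25 log units; within the scatter)), and so does the step from the carbamoylmethyl compound (a 1.3-fold higher number from compound 2 to compound 4 (0.12 log units; within the scatter)). Going by these compounds alone, only the step from the 1H-imidazol-2-yl compound passes the scatter, modestly (a 2.1-fold higher number from compound 1 to compound 4 (0.33 log units; beyond the scatter)), the one such step among the exchanges at this saturated chain carbon. Nothing measured here explains this small spread.

As far as these compounds go, what a carboxylic acid or a primary amine would give on this saturated chain carbon stays open. So does the effect of a longer chain carrying the same ring.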